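The compounds below may be only part of what the source reports. "The series", "measured", "known", "first", "only" and "open" are said of these compounds alone.

Compound 1 `CCCCCCCCCCCCNC(=O)[C@@H](NC(=O)c1ccco1)[C@@H](C)O` carries a furan-2-yl group on the carbonyl carbon attached to the amide-type nitrogen. In a functional assay on MCF7 cells (Homo sapiens) for cytotoxicity, read by MTT assay, with a stated time of 48 h (on this read-out higher numbers stand for weaker inhibition and lower numbers for stronger inhibition), compound 1 gives 67500 nM. Compound 2 `CCCCCCCCCCCCNC(=O)[C@@H](NC(=O)c1cccs1)[C@@H](C)O` differs from it by thiophen-2-yl in place of furan-2-yl on a carbonyl carbon, and in this assay compound 2 gives 30400 nM, which amounts to a 2.2-fold lower number from compound 1 to compound 2 (0.35 log units; beyond the scatter). Compound 3 `CCCCCCCCCCCCCCNC(=O)[C@@H](NC(=O)c1ccco1)[C@@H](C)O` differs from compound 1 in its core by ethyl in place of hydrogen on a saturated chain carbon, ten or more bonds along the chain from an amide-type nitrogen; in this assay compound 3 gives 105000 nM, so that there is a 1.6-fold higher number from compound 1 to compound 3 (0.19 log units; within the scatter), and compound 3 and compound 1 therefore sit within the scatter of each other. Compound 4 `CCCCCCCCCCCCCCNC(=O)[C@@H](NC(=O)c1cccs1)[C@@H](C)O` has not yet been measured. Going by the values given here, it differs from compound 3 by thiophen-2-yl in place of furan-2-yl on a carbonyl carbon, which is the same change as the one made from compound 1 to compound 2, at a place described in the same words. Since that change produced a 2.2-fold lower number from compound 1 to compound 2 (0.35 log units; beyond the scatter) on the core of compound 1, a step of about the same size is expected from compound 3 to compound 4, namely a 2.2-fold lower number from compound 3 to compound 4 (0.34 log units; beyond the scatter). This expectation rests on a single earlier pair, and the core of compound 3 is represented only by 105000 nM, so it is held loosely. Compound 4 is accordingly estimated at 48000 nM in this assay, with a likely range from 24000 nM to 96000 nM.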

Compound 4, half-maximal inhibitory concentration: 36100 nM
Compound 4: the middle estimate sits 1.3-fold (0.12 log units) above what was measured, within the range that was stated.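

In this assay, thiophen-2-yl in place of furan-2-yl on the carbonyl carbon gives a 2.9-fold lower number from compound 3 to compound 4 (0.46 log units; beyond the scatter), and this step agrees with the one seen on the core of compound 1: the same change on two cores in this assay, a 2.2-fold lower number (0.35 log units; beyond the scatter) from compound 1 to compound 2 and a 2.9-fold lower number (0.46 log units; beyond the scatter) from compound 3 to compound 4, 1.3-fold (0.12 log units) apart, within the scatter of two such steps. The other change, ethyl in place of hydrogen on the saturated chain, read now among the thiophen-2-yl compounds, gives a 1.2-fold higher number from compound 2 to compound 4 (0.07 log units; within the scatter), and it too carries over from one core to the other: the same change on two cores in this assay, a 1.6-fold higher number (0.19 log units; within the scatter) from compound 1 to compound 3 and a 1.2-fold higher number (0.07 log units; within the scatter) from compound 2 to compound 4, 1.3-fold (0.12 log units) apart, within the scatter of two such steps. Across these four compounds the two changes therefore behave as independent of each other, but that rests on just two pairs for each change, all in a single assay, and it shows neither that the step would hold on a core further removed from these nor why the thiophen-2-yl compounds give the lower numbers.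

The compounds shown leave open whether the same agreement would appear with a phenyl or pyridin-3-yl group on the carbonyl carbon, or with a shorter or a longer alkyl chain on the amide nitrogen. They also leave open what happens to these steps when the hydroxyl group is replaced by a methyl ether or an amine.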